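A few compounds are considered here, and "the series" means these few. Any claim that something is new, unique, unknown or untested is made for them only; others in the source may bear on it.

Compound 2, `Cc1ccc(/C=C2\CCC/C(=C\c3cccc([N+](=O)[O-])c3)C2=O)cc1`, gives 5.06 in a physicochemical assay for lipophilicity; on this read-out higher numbers stand for higher lipophilicity and lower numbers for lower lipophilicity. Compound 1, `O=C1/C(=C/c2ccccc2)CCC/C1=C\c1cccc([N+](=O)[O-])c1`, gives 5.06, and compound 3, `COc1cc(/C=C2\CCC/C(=C\c3cccc([N+](=O)[O-])c3)C2=O)cc(OC)c1OC`, gives 5.06, so compound 2 stands level with both at the digits shown. Going by the values given here, the only measured step between close structures, no change at the digits printed from compound 1 to compound 2 (within the scatter), went with no shift beyond the scatter. Compound 4, `O=C1/C(=C/c2ccc(F)cc2)CCC/C1=C\c1cccc([N+](=O)[O-])c1`, differs from compound 2 by fluoro in place of methyl on an aromatic carbon. Among the compounds with values here, no measured pair shows a fluoro entering a ring, so the flat methyl step is the only guide, and it argues against any large move. The step in this assay is therefore expected to be small, a number 0.16 log units lower from compound 2 to compound 4 (within the scatter), and may stay within the scatter. Compound 4 is expected near 4.9, between 4.5 and 5.3.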

Compound 4, partition coefficient: 5.06
The estimate for compound 4 lay 0.16 log units below the measured number; the range from low to high includes it.
By their numbers in this assay, from the lowest: compounds 1, 2, 3 and 4 (each within the scatter of the next).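

In this assay, fluoro in place of methyl gave no change at the digits printed from compound 2 to compound 4 (within the scatter) and fluoro in place of hydrogen gave no change at the digits printed from compound 1 to compound 4 (within the scatter) on this aromatic carbon, para to a large group. Hydrogen, methyl and fluoro therefore all read alike at this place, whereas the earlier compounds had shown this only for hydrogen and methyl. Nothing shown here gives a cause for this flat reading. Still open, as far as these compounds go, is whether an amine, a carboxylic acid or a longer chain at this same place would read alike too.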